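The source may report more compounds than this note shows. Statements on the series, on what has been measured and on what is new or still open speak of the compounds shown alone.

Values in a functional assay on MDA-MB-231 cells (Homo sapiens) for antiproliferative activity, read by MTT assay, with a stated time of 72 h; on this read-out higher numbers stand for weaker inhibition and lower numbers for stronger inhibition:
- compound 1 `O=C(NO)c1ccc(NCCOc2ccc3cc2COC/C=C/COCc2cccc(c2)-c2ccnc(n2)N3)cc1`: 8690 nM
- compound 2 `O=C(O)c1ccc(OCCOc2ccc3cc2COC/C=C/COCc2cccc(c2)-c2ccnc(n2)N3)cc1`: 54200 nM
- compound 3 `O=C(CCCCCOc1ccc2cc1COC/C=C/COCc1cccc(c1)-c1ccnc(n1)N2)NO`: 8070 nM

Compound 3 has the lowest number of the three, but it cannot be separated from compound 1, as a 1.1-fold lower number from compound 1 to compound 3 (0.03 log units; within the scatter) shows. Compound 2 stands clearly apart, with a 6.7-fold lower number from compound 2 to compound 3 (0.83 log units; beyond the scatter).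

Next is compound 4 `O=C(O)CCCCCCCOc1ccc2cc1COC/C=C/COCc1cccc(c1)-c1ccnc(n1)N2`, which differs from compound 3 by 2-carboxyethyl in place of hydroxycarbamoyl on a saturated chain carbon, five bonds along the chain from an oxygen on an aromatic ring. Going by the values given here, the hydroxycarbamoyl end gives way to a carboxylic acid end, and no measured step isolates this change. The closest evidence is a 6.2-fold higher number from compound 1 to compound 2 (0.79 log units; beyond the scatter), where 4-carboxyphenoxy replaces (4-(hydroxycarbamoyl)phenyl)amino. The step back from compound 2 to compound 3, given above, is of similar size. Compound 2 is the only measured acid, and its acid sits on an aromatic ring, not on a saturated chain, so the transfer is uncertain. A modest rise in this assay, towards weaker inhibition, is expected, with a 5.2-fold higher number from compound 3 to compound 4 (0.72 log units; beyond the scatter) as the estimated step. The estimated value for compound 4 is 42000 nM, with an expected range of 18000 nM to 95000 nM.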

Compound 4, half-maximal inhibitory concentration: 17100 nM
Estimate against measurement, compound 4: 2.5-fold (0.39 log units) above, and the stated range ends above it.
By their numbers in this assay, from the lowest: compounds 3, 1 and 4 (each within the scatter of the next, the first and the last beyond it); then compound 2.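

In this assay, a carboxylic acid on a saturated chain proves far less damaging than the one aromatic acid suggested: 2-carboxyethyl in place of hydroxycarbamoyl gives only a 2.1-fold higher number from compound 3 to compound 4 (0.33 log units; beyond the scatter). Among the acids, the chain form separates from the aromatic form, with 5-carboxypentyl in place of 4-carboxyphenoxy giving a 3.2-fold lower number from compound 2 to compound 4 (0.50 log units; beyond the scatter), while against the aromatic hydroxycarbamoyl compound the same chain acid gives a 2.0-fold higher number from compound 1 to compound 4 (0.29 log units; within the scatter), so the hydroxycarbamoyl end is not required for activity at this level. No evidence on record speaks to what lies behind these differences.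

Compound 3 and compound 4 differ in chain length as well as in end group, so a longer chain ending in hydroxycarbamoyl or a shorter chain ending in a carboxylic acid would be needed to separate the two changes. Going by these compounds, how an amine or a primary amide at the chain end would read remains open.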